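A Methyl Added on a Saturated Ring Carbon

The source may hold more compounds than are shown below. What is called first, only, known or untested is meant among the compounds shown, and "the series" means these compounds.

Compound 1 `C[C@@H]1CN(c2nc(-c3cnn(C)c3)cnc2C#N)CCN1C(=O)C1CC1`: 1.9
Compound 2 `Cn1cc(-c2ncc(C#N)c(N3CCN(c4cccc(F)c4)CC3)n2)cn1`: 3.2

Of the compounds shown here, two have so far been measured in a physicochemical assay for lipophilicity, read by HPLC; on this read-out lower numbers stand for lower lipophilicity and higher numbers for higher lipophilicity. Among the compounds with values here, of these two numbers, compound 2 stands highest; the only other compound, compound 1, lies lower by a margin that goes beyond the usual scatter of repeated measurements. Within the data shown here, the two differ in more than one place, so no single structural step between them can be read off, and nothing more than their two values can be said of that pair.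

Compound 3 `C[C@@H]1CN(c2nc(-c3cnn(C)c3)ncc2C#N)CCN1c1cccc(F)c1` has not yet been measured. Compared with compound 2 it carries one change: methyl in place of hydrogen on a saturated ring carbon. Among the measured compounds shown here, no step between measured compounds is available to calibrate such a change, so the expectation rests on the change itself, which adds one carbon and no donors or acceptors. In this assay a small upward shift is expected, near the edge of the scatter rather than clearly beyond it. Compound 3 is therefore expected to give about 3.5, with a likely range from 3 to 4. The step this estimate implies, a number 0.30 log units higher from compound 2 to compound 3 (within the scatter), is expected to be small and upward.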

Compound 3, distribution coefficient: 3.3
The estimate for compound 3 lay 0.20 log units above the measured number, within the range that was stated.
By their numbers in this assay, from the lowest: compound 1; then compounds 2 and 3 (each within the scatter of the next).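

Methyl in place of hydrogen on a saturated ring carbon gives the first comparison in this set where two compounds differ in only one place, and in this assay the result is a number 0.10 log units higher from compound 2 to compound 3 (within the scatter). Compound 2 and compound 3 therefore cannot be told apart on this read-out, so this one added carbon, placed on the six-membered non-aromatic ring next to the ring atom that bears a 3-fluorophenyl group, leaves no change that can be distinguished from ordinary variation between repeated measurements. No measurement here accounts for this result.

From the compounds shown here alone, this is one pair at one position, so it remains open whether the same swap would also go unseen on another carbon of this ring or on a different compound, such as compound 1, which carries a cyclopropyl carbonyl group instead of the 3-fluorophenyl group. Going by these compounds, it is also open whether a larger or different group on this same carbon, such as an ethyl chain, a hydroxymethyl group or an amine, would give a step that clearly exceeds the scatter.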